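Adding trifluoromethyl to the fluoro-bearing analog

The compounds below may be only part of what the source reports. "The series", "measured", "known", "first", "only" and "open" are said of these compounds alone.

Of the compounds shown here, three sharing one core have been measured in a functional assay on CWR22R cells (Homo sapiens) for cytotoxicity, read by MTT assay, with a stated time of 72 h; a higher number here means a weaker inhibitor, a lower number a stronger inhibitor. Compound 1 `CC1=C(/C=C/C(=O)/C=C/c2ccccc2C(F)(F)F)C(C)(C)CCC1O` gives 2300 nM. Compound 2 `CC1=C(/C=C/C(=O)/C=C/c2ccc(C(F)(F)F)cc2)C(C)(C)CCC1O` gives 3200 nM. Compound 3 `CC1=C(/C=C/C(=O)/C=C/c2ccccc2F)C(C)(C)CCC1O` gives 3300 nM, the highest of the three numbers, though its nearest neighbour compound 2 sits within the scatter of it and even compound 1, the furthest, is within the scatter as well. The one single-point step among these, from compound 1 to compound 3, is a 1.4-fold higher number from compound 1 to compound 3 (0.16 log units; within the scatter), so the swap of fluoro for trifluoromethyl on an aromatic carbon made no difference that can be trusted. Compound 2 and compound 3 are not linked by a counted step; their two values simply lie close together.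

Compound 4 `CC1=C(/C=C/C(=O)/C=C/c2ccc(C(F)(F)F)cc2F)C(C)(C)CCC1O` has not yet been measured. Relative to compound 3 the change is trifluoromethyl in place of hydrogen on an aromatic carbon. Among the measured compounds shown here, the only step that bears on it, from compound 1 to compound 3, was within the scatter, and compound 2, which already carries a trifluoromethyl group on its ring, gives a number close to compound 3. A step of a 1.1-fold lower number from compound 3 to compound 4 (0.04 log units; within the scatter) in this assay is therefore expected, meaning no change beyond the scatter. Compound 4 is estimated at 3000 nM, with a range from 1500 nM to 6000 nM.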

Compound 4, half-maximal inhibitory concentration: 3800 nM
Beside the measured number, compound 4's estimate is 1.3-fold (0.10 log units) below it, within the range that was stated.
By their numbers in this assay, from the lowest: compounds 1, 2, 3 and 4 (each within the scatter of the next).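

In this assay, trifluoromethyl in place of hydrogen on an aromatic carbon, para to a large group and meta to a fluoro group, gave a 1.2-fold higher number from compound 3 to compound 4 (0.06 log units; within the scatter), so compound 3 and compound 4 cannot be told apart and this position accepts trifluoromethyl without a change that can be trusted. Fluoro in place of hydrogen on an aromatic carbon gave a 1.2-fold higher number from compound 2 to compound 4 (0.07 log units; within the scatter), which is also within the scatter, so the ring carrying both groups reads the same in this assay as the rings carrying only one of them. Nothing available here offers an explanation for these results.

From the compounds shown here alone, all four compounds carry only fluoro or trifluoromethyl on the aromatic ring, so it remains open whether an amine, a carboxylic acid or a methoxy group at this position would shift the number beyond the scatter. The hydroxyl group and the carbonyl are the same throughout, so these compounds also leave open whether an amine in place of that hydroxyl group, or a longer chain in place of the one bearing the carbonyl, would matter more than any change on the ring.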